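Sulfonamide to amide swap on the two-carbon linker

A few compounds are considered here, and "the series" means these few. Any claim that something is new, unique, unknown or untested is made for them only; others in the source may bear on it.

Compound 1 `O=S(=O)(NCCCNc1nccc(-c2c(-c3cccc(F)c3)nc3sccn23)n1)c1cccc(F)c1`: in a functional assay on SK-MEL-28 cells (Homo sapiens) for cytotoxicity, read by MTT assay (on this read-out lower numbers stand for stronger inhibition and higher numbers for weaker inhibition), compound 1 gives 8550 nM.
Compound 2 `Cc1ccc(S(=O)(=O)NCCNc2nccc(-c3c(-c4cccc(F)c4)nc4sccn34)n2)cc1`: compound 2 gives > 20000 nM, a limit of the assay rather than a number.

Compound 2 therefore stands at the limit of > 20000 nM in this assay, at which 1 of the 2 values shown sits. Within the data shown here, the only measured step, an at least 2.3-fold higher number from compound 1 to compound 2 (0.36 log units; beyond the scatter), concerns a different change and gives no direct guide to the next one. Compound 3 `O=C(NCCNc1nccc(-c2c(-c3cccc(F)c3)nc3sccn23)n1)c1ccc(Cl)cc1` differs from compound 2 by (4-chlorophenyl)carbonyl in place of (4-methylphenyl)sulfonyl on an amine nitrogen. Among the measured compounds shown here, with no comparable step measured, compound 3 is expected to stay close to the weak level of the series; the estimated step is a number no higher from compound 2 to compound 3 (the limit leaves the size open). Compound 3 is estimated at 20000 nM, within 5000 nM to 60000 nM, with a fair chance of again reporting only a limit.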

Compound 3, half-maximal inhibitory concentration: 8160 nM
Compound 3: middle estimate off by 2.5-fold (0.39 log units), on the high side; the range from low to high includes it.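

Swapping (4-methylphenyl)sulfonyl for (4-chlorophenyl)carbonyl on this amine nitrogen gives a measurable value, with an at least 2.4-fold lower number from compound 2 to compound 3 (0.38 log units; beyond the scatter). From the compounds shown here alone, compound 2 carries a limit of the assay, so the full size of that step stays open: the limit of > 20000 nM in this assay, at which 1 of the 3 values shown sits. The amide and the other sulfonamide do not separate, with a 1.0-fold lower number from compound 1 to compound 3 (0.02 log units; within the scatter).

Still open, going by these compounds, is whether the change in compound 3 follows the carbonyl or the chlorine, as both differ at once. A (4-methylphenyl)carbonyl or a (4-chlorophenyl)sulfonyl group on the same nitrogen would separate the two.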